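Swapping the aryl group on the shared core of compound 1

This account rests on a few compounds, and the source may have more. Where it says the series, first, only, none or still open, it means among the compounds named here.

Three compounds share one core and differ in the aryl group attached to a nitrogen on an aromatic ring. In a functional assay on HCC827 cells (Homo sapiens) for inhibition, read by MTT assay, with a stated time of 48 h, tested at 10 uM (on this read-out lower numbers stand for less inhibition and higher numbers for more inhibition at the one concentration tested (going by the name of the read-out)), compound 1 `Cc1ccc(Nc2cc(NC(=O)Nc3c(Cl)cccc3Cl)ncn2)cc1F` gives 85.3%, the highest reading of the three, with both other compounds beyond the usual scatter below it. Compound 2 `CCc1ccc(Nc2cc(NC(=O)Nc3cc(OC)cc(OC)c3)ncn2)cc1` gives 66.2% in this assay, and compound 3 `COc1cc(NC(=O)Nc2cc(Nc3ccc(F)c(Cl)c3)ncn2)cc(OC)c1` gives 53.1%. Among the compounds with values here, the one measured step that changes the aryl group on this nitrogen is a number 13.1 percentage points lower from compound 2 to compound 3 (beyond the scatter); it shows that such a swap moves the read-out by a modest amount, here downward.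

Compound 4 `COc1ccc(Br)cc1Nc1cc(NC(=O)Nc2c(Cl)cccc2Cl)ncn1` is not yet measured. It differs from compound 1 at that same nitrogen: 5-bromo-2-methoxyphenyl in place of 3-fluoro-4-methylphenyl on a nitrogen on an aromatic ring. Because the step of a number 13.1 percentage points lower from compound 2 to compound 3 (beyond the scatter) moved the reading only modestly, a shift of similar size is expected here, and since compound 1 already sits high, a small decrease is more likely than a rise, though the direction is uncertain. Compound 4 is therefore estimated at 75% in this assay, within a range from 55% to 90%, which corresponds to an expected step of a number 10.3 percentage points lower from compound 1 to compound 4 (beyond the scatter).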

Compound 4, a percentage reported as inhibition, at one concentration (the size of the read-out at that concentration, not a potency): 53%
Compound 4: middle estimate off by 22 percentage points, on the high side; measured number below the stated range.
By their numbers in this assay, from the lowest: compounds 4 and 3 (each within the scatter of the next); then compound 2; then compound 1.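

In this assay, within the data shown here, the change to 5-bromo-2-methoxyphenyl on a nitrogen on an aromatic ring gives a number 32.3 percentage points lower from compound 1 to compound 4 (beyond the scatter) as a large step, while the only earlier step at this nitrogen, a number 13.1 percentage points lower from compound 2 to compound 3 (beyond the scatter) was modest. This position can therefore move the reading much further than the earlier pair suggested, and with the rest of the molecule unchanged, the high reading of compound 1 depends on its 3-fluoro-4-methylphenyl group. The data shown offer no measurement that explains this drop.

Going by these compounds, the entering group differs from the leaving group in several ways at once, with an oxygen and a bromine appearing while the fluorine and the methyl group go, so it remains open which of these changes matters most for the reading. On these data alone, it also remains open how the reading would respond to a plain phenyl ring or to a phenyl ring carrying an amine or a carboxylic acid at this nitrogen, and whether the same swap would have a similar effect with a different group on the other side of the shared core.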